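The source may hold more compounds than are shown below. What is called first, only, known or untested is meant among the compounds shown, and "the series" means these compounds.

Measured compounds in an assay on isolated protein for binding affinity to Equilibrative nucleoside transporter 1 (Homo sapiens); a lower number here means a stronger inhibitor, a higher number a weaker inhibitor:

- compound 1 `OC[C@H]1O[C@@H](n2cnc3c(NCc4ccco4)ncnc32)[C@H](O)[C@@H]1O`: in this assay compound 1 gives 36300 nM
- compound 2 `Cc1ccc(CSc2ncnc3c2ncn3[C@@H]2O[C@H](CO)[C@@H](O)[C@H]2O)cc1`: in this assay compound 2 gives 457 nM
- compound 3 `OC[C@H]1O[C@@H](n2cnc3c(CSc4ccccc4Cl)ncnc32)[C@H](O)[C@@H]1O`: in this assay compound 3 gives 1780 nM

Compound 3 stands second highest of the three numbers; its nearest neighbour is compound 2 and its furthest is compound 1. The steps seen so far are a 79-fold lower number from compound 1 to compound 2 (1.90 log units; beyond the scatter), a 20-fold lower number from compound 1 to compound 3 (1.31 log units; beyond the scatter) and a 3.9-fold higher number from compound 2 to compound 3 (0.59 log units; beyond the scatter), all three replacing the whole group on the aromatic carbon of the shared core.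

Compound 4 `O=[N+]([O-])c1cccc(SCc2ncnc3c2ncn3[C@@H]2O[C@H](CO)[C@@H](O)[C@H]2O)c1` differs from compound 3 only in 3-nitrophenyl in place of 2-chlorophenyl on a sulfur. Among the compounds with values here, no measured step changes the aryl on the sulfur alone while the rest of the group stays; the closest comparison, a 3.9-fold higher number from compound 2 to compound 3 (0.59 log units; beyond the scatter), was modest and changed both the linkage and the aryl. Within the data shown here, with no direct precedent, compound 4 is expected to stay close to compound 3, with the step of a 1.2-fold lower number from compound 3 to compound 4 (0.07 log units; within the scatter) estimated as small and of uncertain direction. Compound 4 is therefore estimated at 1500 nM in this assay, within a range of 400 nM to 6000 nM.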

Compound 4, half-maximal inhibitory concentration: 4.79 nM
Compound 4: middle estimate off by 310-fold (2.50 log units), on the high side, outside the stated range (below it).
By their numbers in this assay, from the lowest: compound 4; then compound 2; then compound 3; then compound 1.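

In this assay, the aryl on the sulfur is a strong lever: with the saturated chain carbon on that sulfur held fixed, 3-nitrophenyl in place of 2-chlorophenyl gives a 370-fold lower number from compound 3 to compound 4 (2.57 log units; beyond the scatter). Within the data shown here, the earlier steps each replaced the whole group on the aromatic carbon of the shared core, so this is the first reading of the aryl alone, and it is larger than any of them. Nothing at hand bears on why this exchange has so large an effect.

On these data alone, the step changes both the substituent and the name-position on the phenyl, so it remains open whether the nitro group or its location carries the effect; 3-chlorophenyl and 2-nitrophenyl would separate the two. As far as these compounds go, whether nitro can be replaced also remains open, for example by 3-aminophenyl or 3-carboxyphenyl on the same sulfur.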